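A few compounds are considered here, and "the series" means these few. Any claim that something is new, unique, unknown or untested is made for them only; others in the source may bear on it.

Measured compounds in a functional assay on a cell-free system (plasma) for inhibition of thromboxane A2 receptor (Homo sapiens); on this read-out higher numbers stand for weaker inhibition and lower numbers for stronger inhibition:
- compound 1, `CSCSCC1C2CCC(O2)C1C/C=C\CCCC(=O)O`, gives 700 nM
- compound 2, `CCCCSCSCC1C2CCC(O2)C1C/C=C\CCCC(=O)O`, gives 700 nM

Compound 1 stands level with compound 2 at the digits shown; the step of no change at the digits printed from compound 1 to compound 2 (within the scatter) lies within the scatter, so neither is ranked above the other. The unmeasured compound 3, `CCSCC1C2CCC(O2)C1C/C=C\CCCC(=O)O`, differs from compound 1 by methyl in place of methylsulfanyl on a saturated chain carbon bound to a sulfur. Among the measured compounds shown here, the only measured step, that from compound 1 to compound 2, bears on it at a distance: it altered the substituent on a saturated chain carbon bound to a sulfur and left this assay unmoved. Compound 3 instead removes the methylsulfanyl at that place. On this evidence no step beyond the scatter is expected in this assay, and the estimated step of a 1.3-fold higher number from compound 1 to compound 3 (0.11 log units; within the scatter) is set close to zero. Compound 3 is therefore expected to give about 900 nM, within a range from 300 nM to 3000 nM.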

Compound 3, half-maximal inhibitory concentration: 5400 nM
Beside the measured number, compound 3's estimate is 6.0-fold (0.78 log units) below it; the measured number lies above the stated range.
By their numbers in this assay, from the lowest: compounds 1 and 2 (each within the scatter of the next); then compound 3.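

In this assay, this position turns out not to be indifferent: methyl in place of methylsulfanyl on a saturated chain carbon bound to a sulfur gives a 7.7-fold higher number from compound 1 to compound 3 (0.89 log units; beyond the scatter), and methyl in place of butylsulfanyl gives a 7.7-fold higher number from compound 2 to compound 3 (0.89 log units; beyond the scatter). Compound 1 and compound 2 stand level, so the length of the chain on the outer sulfur did not separate them, while exchanging the whole sulfanyl group for methyl does move the number, and both steps are beyond the scatter. Nothing available here accounts for this step.

The compounds shown leave open whether the outer sulfur itself matters or whether other groups at this place would keep the number of compound 1. A methoxy or an ethyl group in place of methylsulfanyl would address that question.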